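Longer Chain on the Sulfur-Linked Analogue: An Estimate

The compounds below may be only part of what the source reports. "The series", "measured", "known", "first", "only" and "open" are said of these compounds alone.

Compound 1 `CCCCCCNc1cc(-c2ccccc2)c(-c2ccccc2)nn1` gives 24000 nM in an assay on microsomes from liver for inhibition of sterol O-acyltransferase 1 (Rattus norvegicus); on this read-out lower numbers stand for stronger inhibition and higher numbers for weaker inhibition.
Compound 2 `CCCCCC(=O)Nc1cc(-c2ccccc2)c(-c2ccccc2)nn1` gives > 300000 nM in this assay, which is a limit of the assay and not a number.
Compound 3 `CCCCCC[S+]([O-])c1cc(-c2ccccc2)c(-c2ccccc2)nn1` gives 75000 nM in this assay.

Among the two numbers that are not limits, compound 3 stands highest; its nearest neighbour is compound 1, and the step is a 3.1-fold higher number from compound 1 to compound 3 (0.49 log units; beyond the scatter). For compound 2 only a limit is known, (the limit of > 300000 nM in this assay, at which 1 of the 3 values shown sits).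

Compound 4 `CCCCCCCC[S+]([O-])c1cc(-c2ccccc2)c(-c2ccccc2)nn1` differs from compound 3 by ethyl in place of hydrogen on a saturated chain carbon, six bonds along the chain from a sulfur. For the measured compounds named here, none of the measured steps bears directly on this change: an at least 12-fold higher number from compound 1 to compound 2 (1.09 log units; beyond the scatter) and an at least 4.0-fold lower number from compound 2 to compound 3 (0.60 log units; beyond the scatter) both alter the atoms that join the chain to the aromatic ring, not the length of the chain itself. With no comparison of chain lengths among the measured compounds, compound 4 is expected to sit close to compound 3, with a step of about a 1.2-fold lower number from compound 3 to compound 4 (0.06 log units; within the scatter), that is, none beyond the scatter. Compound 4 is therefore estimated at 65000 nM, within a range from 20000 nM to 220000 nM.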

Compound 4, half-maximal inhibitory concentration: 92000 nM
For compound 4 the middle estimate is 1.4-fold (0.15 log units) below the measured one; the measured number falls inside the stated range.
By their numbers in this assay, from the lowest: compound 1; then compounds 3 and 4 (each within the scatter of the next). At a limit, above all of these: compound 2.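

Ethyl in place of hydrogen on a saturated chain carbon, six bonds along the chain from a sulfur, leaves the read-out in this assay unchanged within the scatter (a 1.2-fold higher number from compound 3 to compound 4 (0.09 log units; within the scatter)). For the compounds shown here, this is the first comparison in which only the length of the chain differs, and the atoms that join the chain to the aromatic ring stay the same. On this sulfur-linked scaffold, therefore, the longer chain can not be told apart from the shorter one, and nothing among the data shown gives a reason for this result.

On these data alone, whether the same extension would read alike on the nitrogen-linked compound 1 remains open. Also open, as far as these compounds go, is how a still longer chain, or a chain ending in an amine or a carboxylic acid, would behave at this position.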